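Fluorine on the phenyl ring of compound 2

A few compounds are considered here, and "the series" means these few. Any claim that something is new, unique, unknown or untested is made for them only; others in the source may bear on it.

Measured compounds:
compound 1, `CNC(=O)[C@@]12C[C@@H]1[C@@H](n1cnc3c(N)nc(C#Cc4ccccc4)nc31)[C@H](O)[C@@H]2O`, 28%
compound 2, `CNC(=O)[C@@]12C[C@@H]1[C@@H](n1cnc3c(NC4CC4c4ccccc4)nc(C#Cc4ccccc4)nc31)[C@H](O)[C@@H]2O`, 2%

Two compounds share a core and were tested in an assay on CHO cells for displacement of a labelled ligand from adenosine receptor A1 (Homo sapiens), read by scintillation counting, with a stated time of 60 min, tested at 10 uM; a lower number here means less inhibition, a higher number more inhibition at the concentration tested (going by the name of the read-out). Compound 1 gives 28%, while compound 2 gives 2%, which is the lower of the two numbers. For the measured compounds named here, the one step between them, a number 26 percentage points lower from compound 1 to compound 2 (beyond the scatter), came with a 2-phenylcyclopropyl group in place of hydrogen on a nitrogen on an aromatic ring; this step is beyond the scatter and of modest size.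

Compound 3, `CNC(=O)[C@@]12C[C@@H]1[C@@H](n1cnc3c(NC4CC4c4cccc(F)c4)nc(C#Cc4ccccc4)nc31)[C@H](O)[C@@H]2O`, differs from compound 2 in one place: fluoro in place of hydrogen on an aromatic carbon. In other words the phenyl becomes 3-fluorophenyl. Going by the values given here, no measured step involves a change of this kind, so nothing among the two compounds tells how large its effect in this assay might be. With compound 2 already near the bottom of the scale, the step of a number 3 percentage points higher from compound 2 to compound 3 (within the scatter) is expected to stay within the scatter. Compound 3 is therefore estimated at 5%, with a range from -8% to 18%.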

Compound 3, a percentage reported as inhibition, at one concentration (the size of the read-out at that concentration, not a potency): 18%
Compound 3: the middle estimate sits 13 percentage points below what was measured; measured number inside the range.
By their numbers in this assay, from the lowest: compound 2; then compounds 3 and 1 (each within the scatter of the next).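

In this assay, one fluorine on the phenyl ring is enough to shift the read-out, with a number 16 percentage points higher from compound 2 to compound 3 (beyond the scatter), so this place on the ring is not silent, although the step is only modest in size. Set against the compound that carries no group on that nitrogen, the picture also changes: the 2-phenylcyclopropyl group alone lowered the number beyond the scatter, whereas the 2-(3-fluorophenyl)cyclopropyl group gives a number 10 percentage points lower from compound 1 to compound 3 (within the scatter), so the fluorine takes away the clear gap from compound 1 that compound 2 showed. Nothing measured here accounts for why a single atom has this effect.

From the compounds shown here alone, it remains open whether the shift belongs to fluorine itself or simply to having any group at this place, a question that a chloro, methyl or methoxy group there, or a fluoro group elsewhere on the phenyl ring, could help to answer. Going by these compounds, each number in this assay is also a reading at one concentration, so it tells only how strong the effect is at that concentration, and whether a larger group on the ring would push the number further stays unknown.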